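Removing the Bromine from the Aryl Ring of Compound 1

The source may hold more compounds than are shown below. What is called first, only, known or untested is meant among the compounds shown, and "the series" means these compounds.

Compound 1 `COc1cc(/C=N/Nc2nc(-c3cccc(Br)c3)cs2)cc(Br)c1OC`, 86300 nM; compound 2 `COc1cc(/C=N/Nc2nc(-c3cccc(Br)c3)cs2)c(Br)c(Br)c1OC`, 27600 nM.

In a functional assay on U-87MG ATCC cells for inhibition, with U-87 MG (Homo sapiens) as the target, read by MTT assay, with a stated time of 48 h (a higher number here means a weaker inhibitor, a lower number a stronger inhibitor), compound 1 stands at the higher of the two numbers; the nearest is compound 2, reached by a 3.1-fold lower number from compound 1 to compound 2 (0.50 log units; beyond the scatter). Compound 3 `COc1cc(/C=N/Nc2nc(-c3ccccc3)cs2)cc(Br)c1OC` differs from compound 1 by hydrogen in place of bromo on an aromatic carbon. Going by the values given here, only that one step bears on this change, and it points the other way: adding a bromine lowered the number, so taking one away is expected to raise it, by a 1.9-fold higher number from compound 1 to compound 3 (0.27 log units; within the scatter). Compound 3 is therefore expected to give 160000 nM, within 60000 nM to 450000 nM.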

Compound 3, half-maximal inhibitory concentration: 74100 nM
Estimate against measurement, compound 3: 2.2-fold (0.33 log units) above; the range from low to high includes it.
By their numbers in this assay, from the lowest: compound 2; then compounds 3 and 1 (each within the scatter of the next).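

In this assay the change from 3-bromophenyl to phenyl gives a 1.2-fold lower number from compound 1 to compound 3 (0.07 log units; within the scatter) and so leaves the number unchanged within the scatter: this bromo, on an aromatic carbon meta to a large group, can give way to hydrogen without a readable effect. Going by these compounds alone, the one earlier step, a 3.1-fold lower number from compound 1 to compound 2 (0.50 log units; beyond the scatter) with a bromo added on a different aromatic carbon, does not hold for this place. Nothing available explains why the two places differ.

Going by these compounds, whether an amine or a carboxylic acid at this place would shift the number remains open. So does whether removing this bromo would have the same outcome in compound 2.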